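Amide ring variation and THP-1 cytotoxicity: compound 4

The compounds below may be only part of what the source reports. "The series", "measured", "known", "first", "only" and "open" are said of these compounds alone.

Compound 1 `COc1ccc(-c2cnc(NC(=O)c3cccnc3)n2C)cc1` — in a toxicity assay on THP-1 cells (Homo sapiens) for inhibition (on this read-out lower numbers stand for higher toxicity in this test and higher numbers for lower toxicity in this test), a limit, > 100000 nM
Compound 2 `COc1ccc(-c2cnc(NC(=O)c3cccc(O)c3)n2C)cc1` — in this assay a limit, > 100000 nM
Compound 3 `COc1ccc(-c2cnc(NC(=O)c3ccncc3)n2C)cc1` — in this assay a limit, > 100000 nM

Compound 3 stands at the assay limit, and the two other measured values are limits as well: the limit of > 100000 nM in this assay, at which 3 of the 3 values shown sit. The steps a step that the two limits leave unreadable from compound 1 to compound 3 and a step that the two limits leave unreadable from compound 2 to compound 3 therefore cannot be read, and the pair a step that the two limits leave unreadable from compound 1 to compound 2 is equally blank.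

Compound 4 `COc1ccc(-c2cnc(NC(=O)c3ccno3)n2C)cc1` differs from compound 3 by 1,2-oxazol-5-yl in place of pyridin-4-yl on a carbonyl carbon. Among the compounds with values here, no measured step gives a readable size for this kind of exchange, so with the limit of > 100000 nM in this assay, at which 3 of the 3 values shown sit, the expected step is a step that the limit leaves unreadable from compound 3 to compound 4, nothing beyond the scatter. For compound 4 the estimate in this assay is 150000 nM, with a range of 60000 nM to 400000 nM, most probably reported again only as a limit.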

Compound 4, half-maximal cytotoxic concentration: > 100000 nM
Compound 4 was reported as a limit; the forecaster's own chance of this, stated with the estimate: 85%; the middle value lies beyond the limit too.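

Compound 4 is again reported only as a limit, so its steps from compound 1, compound 2 and compound 3 cannot be read: the limit of > 100000 nM in this assay, at which 4 of the 4 values shown sit.

The compounds shown leave open whether any amide ring on the shared core gives a numerical value in this assay.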